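The compounds below may be only part of what the source reports. "The series", "measured", "known", "first", "only" and "open" are said of these compounds alone.

In a physicochemical assay for solubility, measured as kinetic solubility (a lower number here means a less soluble compound, a higher number a more soluble compound), compound 2 `CNc1ccnc2c(O)c(-c3nc(C)n[nH]3)ncc12` gives > 250000 nM as a limit of the assay and not as a number. Compound 1 `Oc1c(-c2nnc(Cc3ccc(Cl)cc3)[nH]2)ncc2cccnc12` gives 219000 nM in this assay and compound 3 `Cc1n[nH]c(-c2ncc3c(NCc4ccc(Cl)cc4)ccnc3c2O)n1` gives 219000 nM in the same read-out. Among the measured compounds shown here, compound 4 `Cc1n[nH]c(-c2ncc3c(N4CCCC4=O)ccnc3c2O)n1` carries 2-oxopyrrolidin-1-yl in place of methylamino on an aromatic carbon and has no measurement yet.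

One measured step alters the methylamino group of compound 2. It puts 4-chlorophenyl in place of hydrogen on a saturated chain carbon bound to a nitrogen on an aromatic ring and gives an at least 1.1-fold lower number from compound 2 to compound 3 (0.05 log units; that floor lies within the scatter) as its size. From the compounds shown here alone, that floor lies within the scatter, and the true size of the step stays open. This larger substituent still left compound 3 at 219000 nM in the measured range, so only a small change is expected here. The expected step is an at least 1.2-fold lower number from compound 2 to compound 4 (0.09 log units; that floor lies within the scatter) and none beyond the scatter is foreseen. The estimate for compound 4 is 200000 nM with a range of 100000 nM to 250000 nM expected from repeat measurements.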

Compound 4, solubility: 109000 nM
Compound 4: middle estimate off by 1.8-fold (0.26 log units), on the high side, and the stated range covers the measured number.
By their numbers in this assay, from the lowest: compounds 4, 1 and 3 (each within the scatter of the next). At a limit, above all of these: compound 2.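

In this assay, the position on the aromatic carbon opposite the ring nitrogen now shows a step that can be read as beyond the scatter: an at least 2.2-fold lower number from compound 2 to compound 4 (0.36 log units; beyond the scatter). The earlier change at this position gave only a floor within the scatter: an at least 1.1-fold lower number from compound 2 to compound 3 (0.05 log units; that floor lies within the scatter). The size of the new step also remains a floor, as compound 2 stands at a limit and not at a number: the limit of > 250000 nM in this assay, at which 1 of the 4 values shown sits.

This single step replaces the hydrogen-bond donor of methylamino and adds both a carbonyl and a five-membered non-aromatic ring, and these differences cannot be separated here. Pyrrolidin-1-yl, which lacks the carbonyl, and acetamido, which lacks the ring, at the same carbon would be the groups to tell them apart.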